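Chloro in place of methyl on the anilide of compound 3

The source may report more compounds than this note shows. Statements on the series, on what has been measured and on what is new or still open speak of the compounds shown alone.

Compound 1 `O=C(Cn1c(=O)c(/C=C\c2ccncc2)nc2ccccc21)Nc1ccc(Cl)cc1`: > 100000 nM
Compound 2 `Cc1ccccc1NC(=O)Cn1c(=O)c(/C=C\c2ccncc2)nc2ccccc21`: > 100000 nM
Compound 3 `Cc1ccc(NC(=O)COc2nc3ccccc3nc2C)cc1`: > 100000 nM

In a functional assay on PC-3 cells (Homo sapiens) for inhibition, read by MTT assay, with a stated time of 24 h (a higher number here means a weaker inhibitor, a lower number a stronger inhibitor), compound 3 gives only a limit, > 100000 nM, not a number. Compound 1 likewise gives only a limit there. Compound 2 gives only a limit as well. Among the measured compounds shown here, the one measured step, a step that the two limits leave unreadable from compound 1 to compound 2, is therefore of unreadable size. Compound 3 thus stands with the others at the limit of > 100000 nM in this assay, at which 3 of the 3 values shown sit.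

Compound 4 `Cc1nc2ccccc2nc1OCC(=O)Nc1ccc(Cl)cc1` differs from compound 3 by chloro in place of methyl on an aromatic carbon. For the measured compounds named here, no measured step carries this change, and the only measured step on the anilide, a step that the two limits leave unreadable from compound 1 to compound 2, shows no readable size. Compound 4 is therefore expected at 150000 nM, with a range from 40000 nM to 600000 nM, most likely again as a limit. The expected step that the limit leaves unreadable from compound 3 to compound 4 is thus estimated as none beyond the scatter.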

Compound 4, half-maximal inhibitory concentration: 68100 nM
Compound 4: middle estimate off by 2.2-fold (0.34 log units), on the high side, within the range that was stated.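

In this assay, among the compounds shown here, compound 4 gives a number, 68100 nM, so 4-methylphenyl to 4-chlorophenyl is the first change on the anilide to yield a readable value. The change gives an at least 1.4-fold lower number from compound 3 to compound 4 (0.16 log units; that floor lies within the scatter), so only a floor is known for the step, and that floor does not by itself establish a real difference. The other compounds give no number: the limit of > 100000 nM in this assay, at which 3 of the 4 values shown sit.

On these data alone, it remains open whether another group at this place, such as an amine, a methoxy group or a carboxylic acid, would lower the number further.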